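The source may hold more compounds than are shown below. What is called first, only, known or untested is meant among the compounds shown, and "the series" means these compounds.

In a physicochemical assay for solubility (on this read-out higher numbers stand for higher solubility and lower numbers for lower solubility), compound 1 `CC[C@@]1(c2ccccc2)COc2c(C(=O)NC)cc(C(=O)N[C@H]3[C@@H]4COC[C@@H]43)cc21` gives >= 152 ug/mL, which is a limit of the assay rather than a number. Compound 2 `CNC(=O)c1cc(C(=O)N[C@H]2[C@@H]3COC[C@@H]32)cc2c1OC[C@H]2c1ccccn1` likewise reaches only a limit, >= 158 ug/mL. Compound 3 `CNC(=O)c1cc(C(=O)NCCC[C@H]2OC[C@H](N)CO2)cc2c1OC[C@H]2c1ccccc1` also stops at a limit, >= 153 ug/mL, so its standing among the known values cannot be ranked; every value seen sits at a limit. Compound 4 `CCC(=O)N1C[C@@H]2[C@H](C1)[C@H]2NC(=O)c1cc(C(=O)NC)c2c(c1)[C@H](c1ccccc1)CO2` differs from compound 3 on an amide-type nitrogen whose other neighbours are a carbonyl carbon: a group of 10 heavy atoms (8 carbon, 1 nitrogen, 1 oxygen; one three-membered non-aromatic ring of carbon only, one five-membered non-aromatic ring with 1 hetero atom) in place of a group of 10 heavy atoms (7 carbon, 1 nitrogen, 2 oxygen; one six-membered non-aromatic ring with 2 hetero atoms), on an amide-type nitrogen. Within the data shown here, no measured pair differs in one place, so the size of this step in this assay is untested; the chemist expects a fall beyond the scatter, noting that the group leaving carries a hydrogen-bond donor and the group entering carries none. Compound 4 is expected near 80 ug/mL, between 25 ug/mL and 160 ug/mL, a step of an at least 1.9-fold lower number from compound 3 to compound 4 (0.28 log units; that floor lies within the scatter).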

Compound 4, solubility: >= 163 ug/mL
Compound 4: a limit, no number; the forecaster's own chance of this, stated with the estimate: 35%; at least 2.0-fold (0.30 log units) between middle value and limit.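

In this assay, compound 3 and compound 4 both stand at limits of the assay, and the step between them cannot be read. The compounds shown leave open how compounds 1 to 4 rank against one another in this assay.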